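Swapping a hydroxyalkyl side chain for a dimethylisoxazole

The source may report more compounds than this note shows. Statements on the series, on what has been measured and on what is new or still open speak of the compounds shown alone.

Compound 1 `COC(c1cc(Cl)c2c(c1Cl)C(=O)N(Cc1c(C)cc(C)[nH]c1=O)CC2)C1CCOC1` — 1100 nM; 494 nM; 47 nM; 7 nM (4 entries)
Compound 2 `Cc1cc(C)c(CN2CCc3c(Cl)cc([C@H](CO)[C@@H]4CCCO4)c(Cl)c3C2=O)c(=O)[nH]1` — 41 nM
Compound 3 `Cc1cc(C)c(CN2CCc3c(Cl)cc([C@H](C)CO)c(Cl)c3C2=O)c(=O)[nH]1` — 129 nM

Of the compounds shown here, three on a shared core have been tested in an assay on cells for inhibition of histone-lysine N-methyltransferase EZH2 (Homo sapiens), read by ELISA, with a stated time of 72 h; on this read-out lower numbers stand for stronger inhibition and higher numbers for weaker inhibition. Compound 1 gives 1100 nM; 494 nM; 47 nM; 7 nM (4 entries), and the spread of the several entries of compound 1 in this assay, 1100 nM; 494 nM; 47 nM; 7 nM (4 entries) shows how widely repeats of this kind can fall. Compound 2 gives 41 nM in this assay . Going by the values given here, compound 3 gives 129 nM, the highest of the two single numbers; the step of a 3.1-fold higher number from compound 2 to compound 3 (0.50 log units; beyond the scatter) is the only measured change of a substituent on that aromatic carbon.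

Compound 4 `Cc1cc(C)c(CN2CCc3c(Cl)cc(-c4c(C)noc4C)c(Cl)c3C2=O)c(=O)[nH]1` is the next compound to be measured. It differs from compound 3 in one place: 3,5-dimethyl-1,2-oxazol-4-yl in place of 1-(hydroxymethyl)ethyl on an aromatic carbon. The step from compound 2 to compound 3 bears on this change in that it too exchanged a ring-bearing group for a small chain at the same carbon, and removing the ring raised the number modestly. Restoring a ring, here an aromatic one, is therefore expected to lower the number rather than raise it, though a five-membered aromatic ring is not the same as the saturated ring of compound 2, so the expected step is a 2.2-fold lower number from compound 3 to compound 4 (0.33 log units; beyond the scatter). The estimate for compound 4 in this assay is 60 nM, expected to fall between 10 nM and 400 nM.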

Compound 4, half-maximal inhibitory concentration: 17 nM
Compound 4: the middle estimate sits 3.5-fold (0.55 log units) above what was measured; the range from low to high includes it.
By their numbers in this assay, from the lowest: compound 4; then compound 2; then compound 3.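

In this assay, this aromatic carbon, ortho to a chloro group, proves to accept a directly attached aromatic ring: 3,5-dimethyl-1,2-oxazol-4-yl in place of 1-(hydroxymethyl)ethyl gives a 7.6-fold lower number from compound 3 to compound 4 (0.88 log units; beyond the scatter), and the same group also improves on the saturated ring-bearing side chain, with a 2.4-fold lower number from compound 2 to compound 4 (0.38 log units; beyond the scatter). The entering group has 0 hydrogen-bond donors and no stereocentre, so among the single-number compounds neither the hydroxyl group nor a defined stereocentre in this substituent is needed for the lowest number. Both steps rest on single entries, however, and repeats of one compound in this assay can lie far apart: the several entries of compound 1 in this assay, 1100 nM; 494 nM; 47 nM; 7 nM (4 entries)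

The compounds shown leave open whether the step belongs to the aromatic ring itself or to its two methyl groups, a distinction that an unsubstituted 1,2-oxazol-4-yl or a phenyl ring at this carbon would help to draw. They also do not tell how this assay would read with an amine or a carboxylic acid on the entering ring.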